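The source may report more compounds than this note shows. Statements on the series, on what has been measured and on what is new or still open speak of the compounds shown alone.

Of the compounds shown here, three have been measured in a functional assay on WiDr cells (Homo sapiens) for inhibition; a lower number here means a stronger inhibitor, a higher number a weaker inhibitor. Compound 1 `CCOC(=O)CNC(=O)N1CC1C#N` carries an ester on a short chain, and in this assay compound 1 gives 31000 nM. Compound 2 `CCOC(=O)c1ccc(NC(=O)N2CC2C#N)cc1` places the ester on an aromatic ring, and in this assay compound 2 gives 2500 nM. Compound 3 `N#CC1CN1C(=O)Nc1ccc(Cl)cc1Cl` has two chlorines on its aromatic ring, and in this assay compound 3 gives 2200 nM. Among these three numbers compound 2 stands second highest: compound 3 lies close beside it, within the usual scatter, while compound 1 gives a clearly higher number, beyond the scatter. Compound 4 `N#CC1CN1C(=O)Nc1ccccc1` is the next compound of the series and is still unmeasured. It differs from compound 2 in one place: hydrogen in place of ethoxycarbonyl on an aromatic carbon. Within the data shown here, no measured pair of this kind gives a guide for the size of this step, so the expectation rests on compound 2 and compound 3 alone. The step from compound 2 to compound 4 is expected to be a small rise, a 1.6-fold higher number from compound 2 to compound 4 (0.20 log units; within the scatter), not clearly beyond the scatter. Compound 4 is therefore estimated at 4000 nM, within a range from 1500 nM to 12000 nM.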

Compound 4, half-maximal inhibitory concentration: 5000 nM
Compound 4: middle estimate off by 1.3-fold (0.10 log units), on the low side; measured number inside the range.
By their numbers in this assay, from the lowest: compounds 3, 2 and 4 (each within the scatter of the next, the first and the last beyond it); then compound 1.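

In this assay, among these compounds, the change to hydrogen on this aromatic carbon, para to a group of 8 heavy atoms, gives a 2.0-fold higher number from compound 2 to compound 4 (0.30 log units; within the scatter) and is the first step that can be read at this position. It shows that the ethoxycarbonyl group, with its 5 heavy atoms and 2 hydrogen-bond acceptors, can leave this place without the number moving beyond the scatter, so the ester is not shown to be needed here. No measured finding is at hand that bears on this step.

The compounds shown leave open whether a carboxylic acid or an amine on this aromatic carbon would give a number beyond the scatter of compound 2 and compound 4. They also leave open whether an ester with a longer chain would behave like ethoxycarbonyl at this position.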